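Hydroxy in place of difluoromethyl: working notes on the series

The compounds below may be only part of what the source reports. "The series", "measured", "known", "first", "only" and "open" are said of these compounds alone.

In a functional assay on HCT-116 cells (Homo sapiens) for antiproliferative activity, read by CellTiter-Glo, with a stated time of 10 days (on this read-out higher numbers stand for weaker inhibition and lower numbers for stronger inhibition), compound 1 (`Cn1ncc(-c2cc(Cl)c3c(=O)[nH]nc(CN)c3c2)c1-c1sc2ccccc2c1C#N`) gives 52 nM and compound 2 (`Cn1ncc(-c2cc(C(F)F)c3c(=O)[nH]nc(CN)c3c2)c1-c1sc2ccccc2c1C#N`) gives 37 nM on the same core. Within the data shown here, the only measured step, a 1.4-fold lower number from compound 1 to compound 2 (0.15 log units; within the scatter) for difluoromethyl in place of chloro, lies within the scatter, so these two numbers do not separate compound 2 from compound 1.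

Compound 3 (`Cn1ncc(-c2cc(O)c3c(=O)[nH]nc(CN)c3c2)c1-c1sc2ccccc2c1C#N`) carries hydroxy in place of difluoromethyl on an aromatic carbon. Among the measured compounds shown here, the measured step is a weak guide to this change, since no measured compound carries hydroxy at this place. For the measured compounds named here, it shows only that one exchange on this carbon stayed within the scatter. A moderately higher number in this assay is expected, meaning weaker inhibition, although a result within the scatter of compound 2 would not be surprising. The estimated change is a 2.3-fold higher number from compound 2 to compound 3 (0.36 log units; beyond the scatter) and remains uncertain in size and direction. For compound 3 the estimated value is 85 nM with an expected range from 20 nM to 350 nM in this measurement.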

Compound 3, half-maximal inhibitory concentration: 188 nM
The estimate for compound 3 lay 2.2-fold (0.34 log units) below the measured number, and the stated range covers the measured number.
By their numbers in this assay, from the lowest: compounds 2 and 1 (each within the scatter of the next); then compound 3.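

In this assay, this aromatic carbon proves sensitive to what it carries: a 5.1-fold higher number from compound 2 to compound 3 (0.71 log units; beyond the scatter), and a 3.6-fold higher number from compound 1 to compound 3 (0.56 log units; beyond the scatter), whereas the earlier exchange of chloro for difluoromethyl stayed within the scatter. Compound 3 therefore stands apart from the pair of compound 1 and compound 2, which this read-out does not separate, and it has the weakest inhibition of the three. The step from difluoromethyl to hydroxy replaces 3 heavy atoms with 1 and adds 1 hydrogen-bond donor and 1 hydrogen-bond acceptor, but nothing measured on these compounds shows which of these differences, if any, accounts for the higher number.

With three groups at one carbon, the series cannot yet show whether the higher number is particular to hydroxy or extends to other small groups. Methoxy would keep the oxygen on this carbon without the hydroxy hydrogen, and an amine or a carboxylic acid at the same place, all on the shared core, would show how far this step can be generalised.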